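Amide-side aryl variation in the thioacetamide series

The source may hold more compounds than are shown below. What is called first, only, known or untested is meant among the compounds shown, and "the series" means these compounds.

Going by the values given here, compound 2 `O=C(CSc1nc(Nc2ccccc2)c2ccccc2n1)Nc1ccc(F)cc1` is one of two compounds measured so far. In a functional assay on NCI-H1975 cells (Homo sapiens) for inhibition, read by MTT assay, with a stated time of 72 h (a higher number here means a weaker inhibitor, a lower number a stronger inhibitor), compound 2 gives 16500 nM. Its nearest neighbour is compound 1 `CCc1cccc(NC(=O)CSc2nc(Nc3ccccc3)c3ccccc3n2)c1`, which in this assay gives 12000 nM; the two numbers stand within the scatter of each other, the only difference being the aryl group on the amide-type nitrogen, and that step is a 1.4-fold higher number from compound 1 to compound 2 (0.14 log units; within the scatter).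

Compound 3 `O=C(CSc1nc(Nc2ccccc2)c2ccccc2n1)Nc1ccc([N+](=O)[O-])cc1` has not yet been measured. Relative to compound 2 it carries nitro in place of fluoro on an aromatic carbon. Among the compounds with values here, no measured pair shows nitro against fluoro. Within the data shown here, the only step that bears on the amide-side aryl group is a 1.4-fold higher number from compound 1 to compound 2 (0.14 log units; within the scatter), and it stayed within the scatter. On that basis the expected step in this assay is a 1.1-fold lower number from compound 2 to compound 3 (0.04 log units; within the scatter), none beyond the scatter in either direction. Compound 3 is therefore expected to give 15000 nM in this assay, in the range 6000 nM to 40000 nM.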

Compound 3, half-maximal inhibitory concentration: 13000 nM
Beside the measured number, compound 3's estimate is 1.2-fold (0.06 log units) above it; the measured number falls inside the stated range.
By their numbers in this assay, from the lowest: compounds 1, 3 and 2 (each within the scatter of the next).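

Nitro in place of fluoro on the amide-side aryl ring leaves the number in this assay within the scatter (a 1.3-fold lower number from compound 2 to compound 3 (0.10 log units; within the scatter)), even though nitro has more heavy atoms and brings hydrogen-bond acceptors that fluoro does not. The step from 3-ethylphenyl to 4-nitrophenyl on the amide-type nitrogen also stays within the scatter (a 1.1-fold higher number from compound 1 to compound 3 (0.03 log units; within the scatter)), so the three aryl groups shown cannot be told apart in this read-out. No independent measurement bears on this result, and the numbers alone offer no explanation for it.

On these data alone, it remains open whether any substituent here can move the number beyond the scatter, for example an amine or a carboxylic acid on the same aromatic carbon. The contribution of the shared core also remains open, as it is unchanged across the compounds shown.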